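The source may hold more compounds than are shown below. What is called first, only, known or untested is meant among the compounds shown, and "the series" means these compounds.

Measured compounds in an assay for inhibition of Amine oxidase [flavin-containing] B (Bos taurus), read by fluorescence, with a stated time of 60 min; a higher number here means a weaker inhibitor, a lower number a stronger inhibitor:
- compound 1, `O=C(NNc1nc2ccccc2nc1Cc1ccccc1)c1ccc(Cl)cc1`: 730000 nM
- compound 2, `O=C(NNc1nc2ccccc2nc1Cc1ccccc1)c1ccc(O)cc1`: 940000 nM
- compound 3, `O=C(Cn1c(=O)c(Cc2ccccc2)nc2ccccc21)N/N=C/c1ccccc1`: 880000 nM

Compound 3 gives the second highest of the three numbers, and all three sit within the usual scatter of one another; the only single-point step shown, a 1.3-fold higher number from compound 1 to compound 2 (0.11 log units; within the scatter), is itself within the scatter. Within the data shown here, no compound here can be called the stronger or weaker inhibitor on these numbers.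

Compound 4, `O=C(Cn1c(=O)c(Cc2ccccc2)nc2ccccc21)N/N=C1/C(=O)Nc2ccccc21`, differs from compound 3 by a group of 11 heavy atoms (8 carbon, 2 nitrogen, 1 oxygen; one five-membered non-aromatic ring with 1 hetero atom, one six-membered aromatic ring of carbon only) in place of a group of 8 heavy atoms (7 carbon, 1 nitrogen; one six-membered aromatic ring of carbon only), on an amide-type nitrogen. Among the measured compounds shown here, no measured step covers a change of this kind; the one step available, from compound 1 to compound 2, alters a substituent on a different part of the molecule and stays flat. The series as a whole shows no movement beyond the scatter, so for compound 4 a step of a 1.3-fold lower number from compound 3 to compound 4 (0.10 log units; within the scatter) in this assay is expected, i.e. nothing clearly beyond the scatter. Compound 4 is therefore estimated at 700000 nM, with a range of 250000 nM to 2000000 nM.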

Compound 4, half-maximal inhibitory concentration: 96000 nM
Beside the measured number, compound 4's estimate is 7.3-fold (0.86 log units) above it; measured number outside the range, below it.
By their numbers in this assay, from the lowest: compound 4; then compounds 1, 3 and 2 (each within the scatter of the next).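

In this assay the change on the amide-type nitrogen gives a step beyond the scatter, a 9.2-fold lower number from compound 3 to compound 4 (0.96 log units; beyond the scatter), whereas compounds 1, 2 and 3 all lay within the scatter of one another. Among these compounds, this position therefore responds to the group it carries, and the series is not flat at this point as the earlier compounds suggested. No available data bear on the reason for this step.

The entering group differs from the leaving one in several features at once, including the five-membered non-aromatic ring and the hydrogen-bond donor, so the compounds shown do not tell which feature goes with the step. As far as these compounds go, how an amine, a carboxylic acid or a longer chain would read at this position also remains open.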